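The source may hold more compounds than are shown below. What is called first, only, known or untested is meant among the compounds shown, and "the series" means these compounds.

Measured compounds in a functional assay on A549 cells (Homo sapiens) for cytotoxicity, read by CCK-8 assay, with a stated time of 72 h; a higher number here means a weaker inhibitor, a lower number a stronger inhibitor:

Compound 1 `C=CCn1c(=O)/c(=C\c2ccccc2OC)[nH]c(=O)/c1=C\c1ccccc1OC` gives 22400 nM.
Compound 2 `C=CCn1c(=O)/c(=C\c2cccc(Br)c2)[nH]c(=O)/c1=C\c1ccccc1OC` gives 5400 nM.

Compound 2 holds the lowest of the two numbers in this assay; its nearest neighbour is compound 1, with a 4.1-fold lower number from compound 1 to compound 2 (0.62 log units; beyond the scatter).

Compound 3 `C=CCn1c(=O)/c(=C\c2ccc(F)c(Br)c2)[nH]c(=O)/c1=C\c1ccccc1OC` differs from compound 2 by fluoro in place of hydrogen on an aromatic carbon. Going by the values given here, no measured step bears directly on this change: the single step known, a 4.1-fold lower number from compound 1 to compound 2 (0.62 log units; beyond the scatter), exchanges the whole aryl group rather than adding a fluoro to it, so it gives no guidance on size or direction here. With nothing to anchor a shift, no step beyond the scatter is expected, and compound 3 is estimated at 5400 nM (range 2500 nM to 12000 nM), which means an expected no change at the digits printed from compound 2 to compound 3 (within the scatter).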

Compound 3, half-maximal inhibitory concentration: "not active" (no number reported)
For compound 3 the study gives words and no number; there is nothing to compare the estimate with.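

Going by these compounds alone, compound 3 is reported only in words, as "not active", so no step from compound 2 to compound 3 can be read. The compounds shown leave open what fluoro in place of hydrogen does to the number in this series. No evidence at hand bears on this result.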